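Phenyl for pyridin-3-yl on the shared core

The source may hold more compounds than are shown below. What is called first, only, known or untested is meant among the compounds shown, and "the series" means these compounds.

Three compounds of this series share one core, shown by compound 1 `Oc1cccc(-c2cc(-c3cccnc3)nc(-c3cccc(Cl)c3)c2)c1`, compound 2 `Oc1ccc(-c2cc(-c3ccc(Cl)cc3)nc(-c3cccnc3)c2)cc1` and compound 3 `Oc1cccc(-c2cc(-c3ccc(Cl)cc3)nc(-c3cccnc3)c2)c1`. In an ADME assay on HEK293 cells (Homo sapiens) for cytotoxicity, read by CCK-8 assay and cell counting, with a stated time of 2 days (on this read-out lower numbers stand for stronger inhibition and higher numbers for weaker inhibition), compound 1 gives "not determined" (no result reported). Compound 2 gives 27500 nM in this assay, and compound 3 gives 39500 nM. Going by the values given here, the one step between measured compounds, a 1.4-fold higher number from compound 2 to compound 3 (0.16 log units; within the scatter), is within the scatter, so compound 3 has the higher of the two numbers without standing apart from compound 2.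

Compound 4 `Oc1cccc(-c2cc(-c3ccccc3)nc(-c3ccc(Cl)cc3)c2)c1` differs from compound 3 by phenyl in place of pyridin-3-yl on an aromatic carbon. Among the compounds with values here, no measured step in this assay touches that change: the only step on record concerns the hydroxyphenyl group and does not involve the group that leaves or the one that enters. The numbers available therefore give no ground to expect a step in either direction beyond the scatter, and the narrow spread between compound 2 and compound 3 suggests that this assay reads much the same across the series.

On that basis compound 4 is expected to give about 35000 nM in this assay, within a range from 12000 nM to 100000 nM, the step from compound 3 being estimated as a 1.1-fold lower number from compound 3 to compound 4 (0.05 log units; within the scatter).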

Compound 4, half-maximal inhibitory concentration: 11600 nM
Beside the measured number, compound 4's estimate is 3.0-fold (0.48 log units) above it, outside the stated range (below it).
By their numbers in this assay, from the lowest: compound 4; then compounds 2 and 3 (each within the scatter of the next).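

On the aromatic carbon next to the ring nitrogen of the shared core, in this assay, phenyl in place of pyridin-3-yl gives a 3.4-fold lower number from compound 3 to compound 4 (0.53 log units; beyond the scatter) and so moves the number beyond the scatter, a modest but readable change. The earlier step, a 1.4-fold higher number from compound 2 to compound 3 (0.16 log units; within the scatter), concerned the hydroxyphenyl group and stayed within the scatter, so this position is the first place among the compounds shown where one exchange separates two numbers, and the exchange amounts to one ring carbon standing for the nitrogen of the pyridin-3-yl group. No measurement shown bears on why the number moves with this exchange.

Going by these compounds, whether the step follows from that nitrogen alone stays open, since a pyridin-4-yl group or a dimethylamino group on the same carbon could separate its presence from its place in the ring. On these data alone, the reading also rests on a single pair, so it remains unknown whether phenyl for pyridin-3-yl gives a like step on compound 2, which carries the 4-hydroxyphenyl group.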